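Swapping the Ether Oxygen for Sulfur on a Chloroaryl Tail

The compounds below may be only part of what the source reports. "The series", "measured", "known", "first", "only" and "open" are said of these compounds alone.

Compound 1, `CC(C)C[C@H](N)c1cc(C(F)(F)F)ccc1N1CCN(C(=O)COc2ccc(Cl)cc2)CC1`, is the weaker of the two measured compounds: in an assay on HEK293 cells for displacement of a labelled ligand from Melanocortin receptor 4 (Homo sapiens) (on this read-out lower numbers stand for stronger inhibition and higher numbers for weaker inhibition), compound 1 gives 2900 nM. Among the measured compounds shown here, compound 2, `COc1ccc(CC(C)C(=O)N2CCN(c3ccc(C(F)(F)F)cc3[C@@H](N)CC(C)C)CC2)cc1`, gives 120 nM in this assay, and the only measured step, a 24-fold lower number from compound 1 to compound 2 (1.38 log units; beyond the scatter), came with a different change, 1-(4-methoxybenzyl)ethyl in place of (4-chlorophenoxy)methyl on a carbonyl carbon.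

Compound 3, `CC(C)C[C@H](N)c1cc(C(F)(F)F)ccc1N1CCN(C(=O)CSc2ccc(Cl)cc2Cl)CC1`, keeps the core of compound 1 and alters only the tail: (2,4-dichlorophenyl)sulfanyl in place of 4-chlorophenoxy on a saturated chain carbon bound to a carbonyl carbon. For the measured compounds named here, no measured step mirrors this exchange. The large step from compound 1 to compound 2 shows that the tail on the carbonyl carbon matters, but it replaced the whole aryloxymethyl piece rather than one atom in it and one ring substituent, so it sets no direction for compound 3. The expectation is therefore a modest step, a 1.9-fold lower number from compound 1 to compound 3 (0.29 log units; within the scatter), leaning slightly toward a lower number but possibly within the scatter. Compound 3 is estimated at 1500 nM in this assay, with a range from 400 nM to 6000 nM.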

Compound 3, inhibition constant: 1500 nM
Beside the measured number, compound 3's estimate shows no gap at the digits printed, within the range that was stated.
By their numbers in this assay, from the lowest: compound 2; then compounds 3 and 1 (each within the scatter of the next).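

In this assay, putting (2,4-dichlorophenyl)sulfanyl in place of 4-chlorophenoxy on a saturated chain carbon bound to a carbonyl carbon gives a 1.9-fold lower number from compound 1 to compound 3 (0.29 log units; within the scatter) and so does not separate the two compounds, even though sulfur replaces the ether oxygen and the ring gains a second chlorine. The other listed comparison gives a 13-fold higher number from compound 2 to compound 3 (1.10 log units; beyond the scatter) for ((2,4-dichlorophenyl)sulfanyl)methyl in place of 1-(4-methoxybenzyl)ethyl on a carbonyl carbon, so the large gap first seen with compound 1 also holds for this sulfur-linked dichlorinated tail. No experimental evidence here accounts for either result.

The sulfur and the second chlorine appear together in compound 3, so these compounds cannot show what either change does alone, and the two could have opposing effects that happen to leave the number within the scatter. Also open, as far as these compounds go, is how this assay would read with a sulfonyl group in place of the sulfur, or with a bromine in place of a chlorine on the ring.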